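This account rests on a few compounds, and the source may have more. Where it says the series, first, only, none or still open, it means among the compounds named here.

Measured in an in vitro ADME assay on microsomes from liver (Homo sapiens) for metabolic stability; on this read-out lower numbers stand for slow clearance and higher numbers for fast clearance:
- compound 1 `CC(C)Nc1nccc(-c2c[nH]nc2-c2ccc(Cl)cc2)n1` gives 0.106 mL/min/kg
- compound 2 `c1cc(-c2c[nH]nc2C2CCCOC2)nc(NC2CCCC2)n1` gives 0.089 mL/min/kg

Compound 2 stands within the scatter of compound 1, so the two values give no order. Compound 3 `Clc1ccc(-c2n[nH]cc2-c2ccnc(NC3CCCC3)n2)cc1` differs from compound 2 by 4-chlorophenyl in place of oxan-3-yl on an aromatic carbon, with 4-chlorophenyl in place of oxan-3-yl on an aromatic carbon. For the measured compounds named here, no measured pair isolates this change. Compound 1 also carries 4-chlorophenyl and gives 0.106 mL/min/kg, so no change beyond the scatter is expected in this assay. The expected change is a 1.2-fold higher number from compound 2 to compound 3 (0.09 log units; within the scatter). The estimate for compound 3 is 0.11 mL/min/kg, with an expected range of 0.05 mL/min/kg to 0.22 mL/min/kg.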

Compound 3, clearance: 0.116 mL/min/kg
Estimate against measurement, compound 3: 1.1-fold (0.02 log units) below, within the range that was stated.
By their numbers in this assay, from the lowest: compounds 2, 1 and 3 (each within the scatter of the next).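

In this assay, 4-chlorophenyl in place of oxan-3-yl on the aromatic carbon gives a 1.3-fold higher number from compound 2 to compound 3 (0.12 log units; within the scatter), so at this position an aromatic ring of carbon only and a non-aromatic ring with one hetero atom cannot be told apart. Cyclopentyl in place of isopropyl on the nitrogen gives a 1.1-fold higher number from compound 1 to compound 3 (0.04 log units; within the scatter), so this change also stays within the scatter. Nothing at hand accounts for either step.

Open, as far as these compounds go, is whether an amine or a carboxylic acid on that aromatic carbon would move the number beyond the scatter. Also open, from the compounds shown here alone, is what a longer chain on the nitrogen would do.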